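Series notes: amine substituent swap on the shared core

The source may report more compounds than this note shows. Statements on the series, on what has been measured and on what is new or still open speak of the compounds shown alone.

Three compounds carry the shared core of compound 1 `COc1ccccc1Oc1ccc2c(NCCCNCc3ccco3)ccnc2c1` with a propane-diamine chain. In a physicochemical assay for acid dissociation, compound 1 gives 9.28. Among the measured compounds shown here, compound 2 `c1ccc(-c2ccc3c(NCCCNCc4ccco4)ccnc3c2)cc1` gives 9.47; the step of a number 0.19 log units higher from compound 1 to compound 2 (within the scatter) is the only one measured between neighbours. Compound 3 `COc1ccc(F)cc1CNCCCNc1ccnc2cc(CCC(C)C)ccc12` gives 9.47 in this assay, level with compound 2 at the digits shown and together with it the highest of the three numbers, within the scatter of compound 1 too.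

Compound 4 `CC(C)CCc1ccc2c(NCCCNCc3ccco3)ccnc2c1` differs from compound 3 in one place: furan-2-yl in place of 5-fluoro-2-methoxyphenyl on a saturated chain carbon bound to an amine nitrogen. For the measured compounds named here, no measured step concerns this position; the step from compound 1 to compound 2 sits on the aromatic carbon of the core and does not bear on it. Compounds 1 and 2 both carry the entering group and stay within the scatter of compound 3, so no step beyond the scatter is expected, a number 0.07 log units lower from compound 3 to compound 4 (within the scatter). Compound 4 is therefore estimated at 9.4, within 9.1 to 9.7.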

Compound 4, acid dissociation constant: 9.47
Estimate against measurement, compound 4: 0.07 log units below, and the stated range covers the measured number.
By their numbers in this assay, from the lowest: compounds 1, 2, 3 and 4 (each within the scatter of the next).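

In this assay, among the compounds shown here, furan-2-yl in place of 5-fluoro-2-methoxyphenyl on a saturated chain carbon bound to an amine nitrogen gives no change at the digits printed from compound 3 to compound 4 (within the scatter), the first measured step at this position. On the aromatic carbon of the core, isopentyl in place of phenyl gives no change at the digits printed from compound 2 to compound 4 (within the scatter), and isopentyl in place of 2-methoxyphenoxy gives a number 0.19 log units higher from compound 1 to compound 4 (within the scatter), so every step now read at either place stays within the scatter. No supporting information bears on this result.

As far as these compounds go, the two groups compared at the chain carbon are both aromatic rings, so a carboxylic acid or a further amine at this place remains open. Also open, from the compounds shown here alone, is whether a longer chain in place of the propane-diamine chain would give a step beyond the scatter.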